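The compounds below may be only part of what the source reports. "The series", "measured", "known", "first", "only" and "open" are said of these compounds alone.

Measured so far:
compound 1 `O=C(O)/C=C/C(=O)c1ccccc1` — 30600 nM
compound 2 `CC(C)c1ccc(C(C)C)c(C(=O)/C=C/C(=O)O)c1` — 4750 nM
compound 3 `O=C(O)/C=C/C(=O)c1ccc(Cl)cc1Cl` — 62900 nM

In a functional assay on HeLa cells (Homo sapiens) for inhibition, read by MTT assay, with a stated time of 72 h (a lower number here means a stronger inhibitor, a higher number a weaker inhibitor), compound 3 stands highest of the three numbers; compound 1 is nearest, with a lower number that is beyond the scatter, and compound 2 is furthest, with a lower number that is also beyond the scatter. Compound 4 `O=C(O)/C=C/C(=O)c1ccc(Cl)cc1` is the next compound to be measured in this assay. Compared with compound 3 the change is hydrogen in place of chloro on an aromatic carbon. For the measured compounds named here, no step between measured compounds is available for this change. Compound 4 keeps one chloro and loses the other, so it sits between compound 3 and compound 1 in structure, and the step is expected to be small, toward a lower number, and probably within the scatter. Compound 4 is estimated at 42000 nM in this assay, range 15000 nM to 110000 nM, a step of a 1.5-fold lower number from compound 3 to compound 4 (0.18 log units; within the scatter).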

Compound 4, half-maximal inhibitory concentration: 25400 nM
Compound 4: the middle estimate sits 1.7-fold (0.22 log units) above what was measured; the measured number falls inside the stated range.
By their numbers in this assay, from the lowest: compound 2; then compounds 4 and 1 (each within the scatter of the next); then compound 3.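

In this assay, hydrogen in place of the chloro ortho to a group of 7 heavy atoms gives a change beyond the scatter (a 2.5-fold lower number from compound 3 to compound 4 (0.39 log units; beyond the scatter)), so this position responds to the change. The remaining chloro gives no change beyond the scatter against the core of compound 1 (a 1.2-fold lower number from compound 1 to compound 4 (0.08 log units; within the scatter)). No measurement at hand bears on the reason for this difference. Steps to compound 2 cannot be read, as it differs in more than one place. From the compounds shown here alone, whether a methoxy group or an amine at the same position would move the number in the same direction stays open.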